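Methoxy in Place of Hydrogen on Compound 2

The source may report more compounds than this note shows. Statements on the series, on what has been measured and on what is new or still open speak of the compounds shown alone.

In an assay on isolated protein for inhibition of vascular endothelial growth factor receptor 1 (Homo sapiens), read by ELISA, with a stated time of 20 min (on this read-out higher numbers stand for weaker inhibition and lower numbers for stronger inhibition), compound 1 `COc1cc2ncnc(Nc3cccc(Cl)c3)c2cc1B1OC(C)(C)C(C)(C)O1` gives only a limit, > 1000 nM. Compound 2 `CC1(C)OB(c2ccc3ncnc(Nc4ccc(F)c(Cl)c4)c3c2)OC1(C)C` likewise gives only a limit in this assay, > 1000 nM. Both values shown sit at the limit of > 1000 nM in this assay, at which 2 of the 2 values shown sit, so compound 2 stands at the ceiling of the read-out, with no number beneath it. Compound 3 `COc1cc2ncnc(Nc3ccc(F)c(Cl)c3)c2cc1B1OC(C)(C)C(C)(C)O1` differs from compound 2 by methoxy in place of hydrogen on an aromatic carbon. Compound 1 already carries methoxy and also sits at its limit, > 1000 nM. Compound 3 is therefore expected to show no step beyond the scatter, a step that the limit leaves unreadable from compound 2 to compound 3, and is estimated at 3000 nM in this assay, between 1000 nM and 30000 nM, most probably reported again only as a limit.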

Compound 3, half-maximal inhibitory concentration: > 1000 nM
Compound 3: a limit, no number (the forecaster's own chance of this, stated with the estimate: 85%); the middle value lies beyond the limit too.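

Going by these compounds alone, compound 3 also gives only a limit, so no step from compound 2 or compound 1 to compound 3 can be read: the limit of > 1000 nM in this assay, at which 3 of the 3 values shown sit. The compounds shown leave open whether methoxy or fluoro in place of hydrogen changes inhibition at all.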